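Replacing furan-2-yl with 3-fluorophenyl on a carbonyl carbon

This account rests on a few compounds, and the source may have more. Where it says the series, first, only, none or still open, it means among the compounds named here.

In a functional assay on A2780 cells (Homo sapiens) for antiproliferative activity, read by fluorescence, with a stated time of 72 h (on this read-out lower numbers stand for stronger inhibition and higher numbers for weaker inhibition), compound 1 (`CN1CCC(C(=O)N2Cc3c(NC(=O)c4ccc(Cl)cc4)n[nH]c3C2(C)C)CC1`) gives 120 nM, and compound 2 (`CN1CCC(C(=O)N2Cc3c(NC(=O)c4cccs4)n[nH]c3C2(C)C)CC1`) gives 30 nM. Compound 3 (`CN1CCC(C(=O)N2Cc3c(NC(=O)c4ccco4)n[nH]c3C2(C)C)CC1`) reads > 5000 nM, which is a limit and not a number. Of the three, only compound 3 stands at the limit of > 5000 nM in this assay, at which 1 of the 3 values shown sits.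

Compound 4 (`CN1CCC(C(=O)N2Cc3c(NC(=O)c4cccc(F)c4)n[nH]c3C2(C)C)CC1`) carries 3-fluorophenyl in place of furan-2-yl on a carbonyl carbon. Three measured steps change this same place. Two of them bring in furan-2-yl and are large: an at least 41-fold higher number from compound 1 to compound 3 (1.61 log units; beyond the scatter) and an at least 160-fold higher number from compound 2 to compound 3 (2.22 log units; beyond the scatter). The third exchanges the other two groups and is modest: a 4.0-fold lower number from compound 1 to compound 2 (0.60 log units; beyond the scatter). Within the data shown here, no measured compound carries 3-fluorophenyl, so the nearest guide is compound 1 at 120 nM, which also has a six-membered aromatic ring at this place. Leaving furan-2-yl is therefore expected to give a large step to a lower number, estimated as an at least 25-fold lower number from compound 3 to compound 4 (1.39 log units; beyond the scatter). For compound 4 the expected value is 200 nM, with an estimated range of 50 nM to 900 nM.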

Compound 4, half-maximal inhibitory concentration: 200 nM
Compound 4: the middle estimate sits on the measured number at the digits printed; low and high end bracket the measured number.
By their numbers in this assay, from the lowest: compound 2; then compounds 1 and 4 (each within the scatter of the next). At a limit, above all of these: compound 3.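

In this assay, the loss seen with furan-2-yl on this carbonyl carbon proves not to be general to changing the group here, since 3-fluorophenyl gives an at least 25-fold lower number from compound 3 to compound 4 (1.39 log units; beyond the scatter), while its difference from 4-chlorophenyl is only a 1.7-fold higher number from compound 1 to compound 4 (0.22 log units; within the scatter). The two groups with a six-membered aromatic ring therefore cannot be told apart, whereas thiophen-2-yl remains separate from 3-fluorophenyl, with a 6.7-fold higher number from compound 2 to compound 4 (0.82 log units; beyond the scatter). Compound 3 stays a limit and not a number, so furan-2-yl remains the one clear outlier among these groups, with its true distance unknown: the limit of > 5000 nM in this assay, at which 1 of the 4 values shown sits.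

The compounds shown leave open how a pyridine ring, or an amine or a carboxylic acid on the phenyl ring, would read at this carbonyl carbon. They also leave open why furan-2-yl and thiophen-2-yl lie so far apart.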